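This account rests on a few compounds, and the source may have more. Where it says the series, first, only, none or still open, it means among the compounds named here.

Compound 2 `CC1(C)[C@@H]2CC[C@@]1(C)/C(=N/NC(=O)c1ccco1)C2` carries a furan-2-yl group on a carbonyl carbon. In an ADME assay on MDCK cells (Canis lupus familiaris) for cytotoxicity, read by MTT assay, with a stated time of 48 h (a higher number here means that more compound is tolerated, a lower number that less compound is tolerated), compound 2 gives 1090000 nM. Within this assay compound 2 holds the only number that is shown; the one further value is a limit. That limit belongs to compound 1 `CCCC(=O)N/N=C1\C[C@H]2CC[C@]1(C)C2(C)C`, which in this assay gives > 1190000 nM, a limit of the assay rather than a number. Among the measured compounds shown here, the one measured step, an at least 1.0-fold lower number from compound 1 to compound 2 (0.03 log units; that floor lies within the scatter), sits within the scatter. Its floor rests on (the limit of > 1190000 nM in this assay, at which 1 of the 2 values shown sits). Compound 3 `CC1(C)[C@@H]2CC[C@@]1(C)/C(=N/NC(=O)c1ccc(Br)cc1)C2` differs from compound 2 by 4-bromophenyl in place of furan-2-yl on a carbonyl carbon. This exchange sits on the same carbonyl carbon as the measured step, and because that step, an at least 1.0-fold lower number from compound 1 to compound 2 (0.03 log units; that floor lies within the scatter), stayed within the scatter, no change beyond the scatter is expected for compound 3 in this assay. Compound 3 is estimated at 900000 nM, with a range from 400000 nM to 1190000 nM. That estimate is expected to mean a 1.2-fold lower number from compound 2 to compound 3 (0.08 log units; within the scatter), inside the scatter.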

Compound 3, half-maximal cytotoxic concentration: > 822000 nM
Compound 3 ended at the assay's limit; the forecaster's own chance of this, stated with the estimate: 30%; the middle value lies beyond the limit too.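

In this assay compound 3 gives > 822000 nM, a limit of the assay and not a number, so the steps linking compound 2 and compound 1 to compound 3 cannot be read. The compounds shown leave open how 4-bromophenyl compares with furan-2-yl or propyl on the carbonyl carbon.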